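Shifting the chlorines on the benzyl ether of compound 1

The source may hold more compounds than are shown below. What is called first, only, known or untested is meant among the compounds shown, and "the series" means these compounds.

Compound 1 `Clc1ccc(CO/N=C/c2c(-c3ccc4ccccc4c3)nc3occn23)cc1Cl`: 370 nM
Compound 2 `Clc1cccc(-c2nc3sccn3c2/C=N/OCc2ccc(Cl)c(Cl)c2)c1`: 1100 nM
Compound 3 `Clc1ccc(CO/N=C/c2c(-c3ccccc3)nc3sccn23)cc1Cl`: 580 nM

In an assay on HepG2 cells for agonist activity at nuclear receptor subfamily 1 group I member 3 (Homo sapiens), read by a luciferase reporter, with a stated time of 23 h (on this read-out lower numbers stand for an effect already at smaller amounts and higher numbers for an effect only at larger amounts of compound), compound 1 gives 370 nM, the lowest of the three numbers. Compound 3 gives 580 nM, a gap to compound 1 that is within the scatter. Compound 2 gives 1100 nM, a gap to compound 1 that is beyond the scatter. Within the data shown here, the one single-place step among the measured compounds, a 1.9-fold lower number from compound 2 to compound 3 (0.28 log units; within the scatter), concerns a chlorine on the ring that sits on the shared core and not the benzyl ether.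

Compound 4 `Clc1ccc(CO/N=C/c2c(-c3ccc4ccccc4c3)nc3occn23)c(Cl)c1` differs from compound 1 by 2,4-dichlorophenyl in place of 3,4-dichlorophenyl on a saturated chain carbon bound to an oxygen on an unsaturated carbon. Among the measured compounds shown here, no measured step moves a chlorine from one position of the benzyl ring to another, so no step bears directly on this change; the only step touching a chlorine anywhere stayed within the scatter. The account therefore expects no step beyond the scatter from compound 1 to compound 4, that is, a 1.1-fold higher number from compound 1 to compound 4 (0.06 log units; within the scatter). For compound 4 the estimate is 420 nM, with a range from 150 nM to 1200 nM.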

Compound 4, half-maximal effective concentration: 1500 nM
Estimate against measurement, compound 4: 3.6-fold (0.55 log units) below; the whole stated range lies below it.
By their numbers in this assay, from the lowest: compounds 1, 3, 2 and 4 (each within the scatter of the next, the first and the last beyond it).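

Moving one chlorine on the benzyl ring, while the group keeps the same atoms, gives a 4.1-fold higher number from compound 1 to compound 4 (0.61 log units; beyond the scatter) in this assay, the only step shown that lies beyond the scatter. At this position, on a saturated chain carbon bound to an oxygen on an unsaturated carbon, 3,4-dichlorobenzyl and 2,4-dichlorobenzyl are therefore not interchangeable, whereas the chlorine change on the ring attached to the shared core, a 1.9-fold lower number from compound 2 to compound 3 (0.28 log units; within the scatter), stayed within the scatter. Nothing in the available data accounts for the difference between the two arrangements.

As far as these compounds go, it remains open whether the same step would appear on the core of compound 2 or compound 3, both of which carry 3,4-dichlorobenzyl. From the compounds shown here alone, it is also open how a benzyl ring bearing a methoxy group or a trifluoromethyl group would compare with either dichlorobenzyl group.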